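Notes on the aryl group: compound 2 to compound 3

This account rests on a few compounds, and the source may have more. Where it says the series, first, only, none or still open, it means among the compounds named here.

- compound 1 `O=C(Cc1csc2nc(-c3ccc(Br)cc3)cn12)N/N=C/c1ccccc1`: 12900 nM
- compound 2 `COc1cccc(OC)c1/C=N/NC(=O)Cc1csc2nc(-c3ccc(Br)cc3)cn12`: 12900 nM

In a functional assay on BT-549 cells (Homo sapiens) for inhibition, read by sulforhodamine B assay, with a stated time of 48 h (a lower number here means a stronger inhibitor of growth, a higher number a weaker inhibitor of growth), compound 2 gives 12900 nM, level with compound 1. Compound 3 `O=C(Cc1csc2nc(-c3ccc(Br)cc3)cn12)N/N=C/c1ccc(Cl)cc1Cl` is still unmeasured and differs from compound 2 as follows: 2,4-dichlorophenyl in place of 2,6-dimethoxyphenyl on a carbon with a double bond to nitrogen. Among the measured compounds shown here, one measured step bears on this place, no change at the digits printed from compound 1 to compound 2 (within the scatter). That single step is thin evidence, and no chlorine-bearing group has been measured here. No step beyond the scatter is therefore expected, and the estimated step is a 1.3-fold lower number from compound 2 to compound 3 (0.11 log units; within the scatter). The expected value for compound 3 is 10000 nM, with an estimated range of 4000 nM to 25000 nM.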

Compound 3, concentration for 50% growth inhibition: 25700 nM
For compound 3 the middle estimate is 2.6-fold (0.41 log units) below the measured one, outside the stated range (above it).
By their numbers in this assay, from the lowest: compounds 1, 2 and 3 (each within the scatter of the next).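

In this assay a chlorine-bearing aryl group at this place, 2,4-dichlorophenyl, gives a 2.0-fold higher number from compound 2 to compound 3 (0.30 log units; within the scatter) and a 2.0-fold higher number from compound 1 to compound 3 (0.30 log units; within the scatter) on a carbon with a double bond to nitrogen. Phenyl, 2,6-dimethoxyphenyl and 2,4-dichlorophenyl therefore remain unseparated here, and the swap of two methoxy groups for two chlorines yields no step beyond the scatter. No available data account for this result.

Going by these compounds, whether an amine or a carboxylic acid on this aryl ring would give a step beyond the scatter remains open. On these data alone, a single chlorine on the ring also remains open.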